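The compounds below may be only part of what the source reports. "The series", "measured", "known", "first", "only" and "open" are said of these compounds alone.

Of the compounds shown here, two built on a shared core have been measured in a functional assay on MCF7 cells (Homo sapiens) for antiproliferative activity, read by MTT assay; on this read-out lower numbers stand for stronger inhibition and higher numbers for weaker inhibition. Compound 1 `COc1ccc([C@@H]2C(c3ccc(C)s3)C(=O)N2c2cc(OC)c(OC)c(OC)c2)cc1` gives 250 nM, and compound 2 `COc1ccc([C@@H]2[C@@H](C(=O)c3ccsc3)C(=O)N2c2cc(OC)c(OC)c(OC)c2)cc1` gives 470 nM. Compound 1 has the lower of the two numbers, but its gap to compound 2 lies within the usual scatter of repeated measurements, so the two cannot be told apart on these data.

The unmeasured compound 3 `COc1ccc([C@@H]2C(c3ccoc3)C(=O)N2c2cc(OC)c(OC)c(OC)c2)cc1` is built from compound 1 by a single change: furan-3-yl in place of 5-methylthiophen-2-yl on a saturated ring carbon. Among the compounds with values here, no step between two measured compounds of this kind is available, so nothing here tells how far the number moves when one five-membered aromatic ring is exchanged for another on this saturated ring carbon. Since the two measured compounds lie within the scatter of each other, no movement beyond the scatter is expected in either direction. The step expected from this change is a 1.6-fold higher number from compound 1 to compound 3 (0.20 log units; within the scatter). In this assay compound 3 is expected to give about 400 nM, within a range from 150 nM to 1100 nM.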

Compound 3, half-maximal inhibitory concentration: 150 nM
The estimate for compound 3 lay 2.7-fold (0.43 log units) above the measured number; low and high end bracket the measured number.
By their numbers in this assay, from the lowest: compounds 3, 1 and 2 (each within the scatter of the next, the first and the last beyond it).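

The first step readable at this saturated ring carbon is a 1.7-fold lower number from compound 1 to compound 3 (0.22 log units; within the scatter) in this assay and it shows that one five-membered aromatic ring can be exchanged for another here without a movement that can be told from the scatter. The exchange is not a small one on paper: sulfur gives way to oxygen, the methyl group is gone, the ring is attached through a different ring atom, and yet compound 1 and compound 3 cannot be told apart on this read-out. Nothing measured on these compounds offers an explanation for this result.

With those differences all bundled into one step, the compounds shown leave open what each contributes alone, a question that an unsubstituted thiophen-2-yl or a 5-methylfuran-2-yl group at the same carbon would address. They also leave open whether this position accepts groups of a different kind, such as a plain phenyl ring, a primary amine, a carboxylic acid or a longer alkyl chain, where the number might move well beyond the scatter in either direction.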